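The compounds below may be only part of what the source reports. "The series", "measured", "known", "first", "only" and "open" are said of these compounds alone.

Of the compounds shown here, two have been tested in a functional assay on the whole organism (strain Swiss albino) with Mus musculus as the target; on this read-out higher numbers stand for an effect only at larger amounts of compound and lower numbers for an effect already at smaller amounts. Compound 1, with the structure `COc1cc(/C=N/Cc2cccnc2)ccc1O`, gives 6.44 mg/kg in this assay, the lower of the two numbers recorded so far. Compound 2, with the structure `c1cncc(CN=C2CCCCC2)c1`, gives 14.2 mg/kg in this assay, a higher number whose gap to compound 1 lies beyond the scatter of repeated measurement, so compound 1 acts at the smaller dose of the pair.

Compound 3, with the structure `COc1ccc(/C=N/Cc2cccnc2)cc1OC`, has not yet been measured in this assay. It differs from compound 1 in one place only: methyl in place of hydrogen on an oxygen on an aromatic ring, so that the hydroxy group of compound 1 becomes a methoxy group. Among the measured compounds shown here, no measured pair in this set shows what such a change does, so the expected step from compound 1 to compound 3 is taken as small, a 1.2-fold higher number from compound 1 to compound 3 (0.09 log units; within the scatter), and not clearly beyond the scatter. On that basis compound 3 is expected to give about 8 mg/kg in this assay, most likely between 4 mg/kg and 16 mg/kg.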

Compound 3, dose for half-maximal effect: 11.7 mg/kg
Compound 3: middle estimate off by 1.5-fold (0.17 log units), on the low side, and the stated range covers the measured number.
By their numbers in this assay, from the lowest: compounds 1, 3 and 2 (each within the scatter of the next, the first and the last beyond it).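

Among the compounds shown here, compounds 1 and 3 form the first pair here that differs in only one place, so they give the first direct reading of this position. In this assay the change from hydroxy to methoxy, with methyl in place of hydrogen on an oxygen on an aromatic ring, gives a 1.8-fold higher number from compound 1 to compound 3 (0.26 log units; within the scatter) and so cannot be told apart from repeat-measurement noise; for this pair, the free hydroxy hydrogen is not needed for an effect in this dose range. As far as these compounds go, no other measurement accompanies the pair, so the basis of this result remains unknown.

From the compounds shown here alone, it remains open whether an ethyl group or a longer chain on this oxygen, or an amine in place of the hydroxy group, would stay within the scatter of compound 1. This single pair also cannot show whether the same change behaves alike on a different core.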